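Methoxy removal on the shared core: expected inhibition

The compounds below may be only part of what the source reports. "The series", "measured", "known", "first", "only" and "open" are said of these compounds alone.

Among the compounds with values here, compound 2 `COc1ccc2c(c1)c(-c1cc(C(F)(F)F)ccn1)cn2S(=O)(=O)c1ccc(C)cc1` gives 35.9% in a functional assay on A549 cells (Homo sapiens) for inhibition, tested at 100 uM (a lower number here means a weaker effect, a higher number a stronger effect of the compound at the concentration tested), and stands highest of the two numbers so far. Compound 1 `COc1ccc2c(-c3cc(C(F)(F)F)c(C#N)c(-c4cn(S(=O)(=O)c5ccc(C)cc5)c5cc(OC)ccc45)n3)cn(S(=O)(=O)c3ccc(C)cc3)c2c1` gives 21.2% in this assay, a gap beyond the usual scatter. Compound 3 `Cc1ccc(S(=O)(=O)n2cc(-c3cc(C(F)(F)F)ccn3)c3ccccc32)cc1` is not yet measured; it differs from compound 2 by hydrogen in place of methoxy on an aromatic carbon. Within the data shown here, no pair of measured compounds isolates this change, so its size is not known from the series. The expected step is a number 5.9 percentage points lower from compound 2 to compound 3 (within the scatter), a small loss or none beyond the scatter. Compound 3 is estimated at 30%, within the range 15% to 45%.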

Compound 3, a percentage reported as inhibition, at one concentration (the size of the read-out at that concentration, not a potency): 30.5%
The estimate for compound 3 lay 0.5 percentage points below the measured number; low and high end bracket the measured number.
By their numbers in this assay, from the lowest: compounds 1, 3 and 2 (each within the scatter of the next, the first and the last beyond it).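

In this assay, within the data shown here, hydrogen in place of methoxy on an aromatic carbon gives a number 5.4 percentage points lower from compound 2 to compound 3 (within the scatter), the first direct reading of this change. At this position, the methoxy is therefore not needed to retain the read-out at the concentration tested. Nothing measured on these compounds accounts for the step.

As far as these compounds go, whether an amine, a carboxylic acid or a longer alkoxy chain on this carbon would move the read-out beyond the scatter remains open. Also open, from the compounds shown here alone, is whether the same change would give a similar step on the core of compound 1.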